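The source may report more compounds than this note shows. Statements on the series, on what has been measured and on what is new or still open speak of the compounds shown alone.

Compound 1 `O=C(NCCSc1nonc1/C(=N/O)Nc1ccc(F)c(C(F)F)c1)C1CS(=O)(=O)C1` gives 70 nM in an assay for inhibition of Indoleamine 2,3-dioxygenase 1 (Homo sapiens), read by fluorescence, with a stated time of 1 h; a higher number here means a weaker inhibitor, a lower number a stronger inhibitor.
Compound 2 `C[C@@H](CSc1nonc1/C(=N/O)Nc1ccc(F)c(Br)c1)NC(=O)CS(N)(=O)=O` gives 93 nM in this assay.
Compound 3 `CS(=N)(=O)CC(=O)NCCSc1nonc1/C(=N/O)Nc1ccc(F)c(Br)c1` gives 61 nM in this assay.

Compound 3 shows the smallest of the three numbers, yet its distances to compound 1 and to compound 2 both fall within the scatter, so no ranking among the three can be drawn. Compound 4 `CS(=O)(=O)NCCSc1nonc1/C(=N/O)Nc1ccc(F)c(Br)c1` differs from compound 3 in one place: a group of 4 heavy atoms (1 carbon, 2 oxygen, 1 sulfur; no ring) in place of a group of 7 heavy atoms (3 carbon, 1 nitrogen, 2 oxygen, 1 sulfur; no ring), on an amine nitrogen. Among the measured compounds shown here, no measured pair covers this change, and the three side chains already varied all land close together, so the step from compound 3 to compound 4 is expected to be small, none beyond the scatter, as a 1.3-fold higher number from compound 3 to compound 4 (0.12 log units; within the scatter). Compound 4 is therefore estimated at 80 nM, with a range from 35 nM to 180 nM.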

Compound 4, half-maximal inhibitory concentration: 270 nM
The estimate for compound 4 lay 3.4-fold (0.53 log units) below the measured number, and the stated range ends below it.
By their numbers in this assay, from the lowest: compounds 3, 1 and 2 (each within the scatter of the next); then compound 4.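

In this assay there is a 4.4-fold higher number from compound 3 to compound 4 (0.65 log units; beyond the scatter) when methylsulfonyl takes the place of the group of 7 heavy atoms on the amine nitrogen. This shows that the number responds to what this nitrogen carries, by more than the scatter covers. Nothing measured here accounts for the step.

The compounds shown leave open which part of the larger group matters, since one step changes the whole group at once. A methylsulfonylacetyl group or an acetyl group on this nitrogen could place the answer closer to compound 3 or to compound 4.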